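Swapping the 3-hydroxyazetidin-1-yl group of compound 2

A few compounds are considered here, and "the series" means these few. Any claim that something is new, unique, unknown or untested is made for them only; others in the source may bear on it.

Among the compounds with values here, in a physicochemical assay for solubility, in phosphate buffer, with a stated time of 2 h (on this read-out higher numbers stand for higher solubility and lower numbers for lower solubility), compound 1 `Cc1nc(-c2ccc(-c3ccccc3)cc2)sc1-c1nnc(N2CCN(C)CC2)o1` gives 45000 nM and compound 2 `Cc1nc(-c2ccc(-c3ccccc3)cc2)sc1-c1nnc(N2CC(O)C2)o1` gives 150000 nM, the higher of the two numbers so far. Compound 3 `Cc1nc(-c2ccc(-c3ccccc3)cc2)sc1-c1nnc(NN)o1` keeps the shared core but carries aminoamino in place of 3-hydroxyazetidin-1-yl on an aromatic carbon. Within the data shown here, only one measured step bears on this change: a 3.3-fold higher number from compound 1 to compound 2 (0.52 log units; beyond the scatter). That modest step brought in 3-hydroxyazetidin-1-yl in place of 4-methylpiperazin-1-yl, also on an aromatic carbon, and it shows that a swap there can move the number beyond the scatter. Among the measured compounds shown here, no measured compound carries a group without a ring at this carbon, so the direction remains uncertain. A modest fall of similar size is expected, and the estimated change is a 2.5-fold lower number from compound 2 to compound 3 (0.40 log units; beyond the scatter). Compound 3 is estimated at 60000 nM, with an expected range of 15000 nM to 180000 nM.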

Compound 3, solubility: 77000 nM
Compound 3: middle estimate off by 1.3-fold (0.11 log units), on the low side, within the range that was stated.
By their numbers in this assay, from the lowest: compounds 1, 3 and 2 (each within the scatter of the next, the first and the last beyond it).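

In this assay, within the data shown here, aminoamino, the one group here without a ring on this aromatic carbon, gives a 1.9-fold lower number from compound 2 to compound 3 (0.29 log units; within the scatter) and a 1.7-fold higher number from compound 1 to compound 3 (0.23 log units; within the scatter). Neither step leaves the scatter, so aminoamino cannot be told apart from 3-hydroxyazetidin-1-yl or from 4-methylpiperazin-1-yl, although the two ring-bearing groups do stand apart from each other with a 3.3-fold higher number from compound 1 to compound 2 (0.52 log units; beyond the scatter); at this carbon, then, a ring is not required for a number within the span of these compounds. Nothing measured here offers an explanation for these numbers.

From the compounds shown here alone, whether a carboxylic acid or a longer chain ending in a hydroxyl at this carbon would stay within that span remains open. So does whether a dimethylamino group, which keeps a single nitrogen and no ring, would behave like aminoamino.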